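Methoxy to Trifluoromethoxy: What Happens to Plasma Binding?

A few compounds are considered here, and "the series" means these few. Any claim that something is new, unique, unknown or untested is made for them only; others in the source may bear on it.

Of the compounds shown here, two built on a shared core have been measured so far. In an ADME assay on a cell-free system (plasma, Mus musculus) for protein binding, compound 1 `CNc1nccc(N2CC[C@H](NC(=O)Nc3cccc(C#N)c3)C2)n1` gives 91.5%, while compound 2 `CNc1nccc(N2CC[C@H](NC(=O)Nc3ccc(OC)cc3)C2)n1` gives 82.1%. Of the two, compound 2 therefore leaves more of its material unbound.

The next candidate, compound 3 `CNc1nccc(N2CC[C@H](NC(=O)Nc3ccc(OC(F)(F)F)cc3)C2)n1`, differs from compound 2 in one group: trifluoromethyl in place of methyl on an oxygen on an aromatic ring. Trifluoromethyl takes the place of methyl on an oxygen on an aromatic ring, so methoxy becomes trifluoromethoxy.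

For the measured compounds named here, only one measured step bears on this change, and it is a swap of a whole group on an amide-type nitrogen: a 2.1-fold higher unbound fraction from compound 1 to compound 2 (0.32 log units; beyond the scatter). That step shows that a change in this part of the molecule can shift this assay beyond the scatter. However, no fluorinated comparison has been measured, so the direction remains a judgement. The expected change is a 2.2-fold lower unbound fraction from compound 2 to compound 3 (0.35 log units; beyond the scatter), a lower unbound fraction of roughly that earlier modest size. Compound 3 is estimated at 92%, with an expected range of 85% to 97%.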

Compound 3, plasma protein binding: 98.1%
Compound 3: the middle estimate sits 4.2-fold (0.62 log units) (unbound fraction) above what was measured; the measured number lies above the stated range.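

In this assay, the step from methyl to trifluoromethyl on the oxygen gives a 9.4-fold lower unbound fraction from compound 2 to compound 3 (0.97 log units; beyond the scatter), which is larger than the earlier swap of the whole group on the amide-type nitrogen, a 2.1-fold higher unbound fraction from compound 1 to compound 2 (0.32 log units; beyond the scatter). So this oxygen substituent is a sensitive spot in the series: exchanging one methyl for a trifluoromethyl moves the free share further than replacing the entire aromatic group did. The percentages alone understate this: compound 2 gives 82.1% and compound 3 gives 98.1%, which looks like only a small rise, while the free share left over shrinks by far more; no measurement shown here accounts for the size of this step.

Going by these compounds, it remains open whether difluoromethyl on the same oxygen would land between compound 2 and compound 3, which would show whether the effect grows step by step with each fluorine or appears only with the full trifluoromethyl. Also open, on these data alone, is how a longer chain such as ethyl on that oxygen, or a free hydroxyl or a carboxylic acid in place of the whole trifluoromethoxy, would read in this assay.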